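The compounds below may be only part of what the source reports. "The series", "measured", "known", "first", "only" and "open" are said of these compounds alone.

Values in a functional assay on HCC827 cells (Homo sapiens) for antiproliferative activity, read by MTT assay, with a stated time of 72 h; on this read-out higher numbers stand for weaker inhibition and lower numbers for stronger inhibition:
- compound 1 `CN1CCN(c2ccc(Nc3ncc4nc(Sc5ccccc5)n(C5CCOCC5)c4n3)cc2)CC1`: 42.6 nM
- compound 2 `CC(C)n1c(Sc2ccccc2)nc2cnc(Nc3ccc(N4CCN(C)CC4)cc3)nc21`: 290 nM
- compound 3 `CN1CCN(c2ccc(Nc3ncc4nc(SCc5ccccc5)n(C5CCOCC5)c4n3)cc2)CC1`: 107 nM

Compound 3, at 107 nM, holds the middle place of the three numbers, with compound 1 lower and compound 2 higher.

Compound 4 `CN1CCN(c2ccc(Nc3ncc4nc([S+]([O-])Cc5ccccc5)n(C5CCOCC5)c4n3)cc2)CC1` differs from compound 3 by one change: a group of 9 heavy atoms (7 carbon, 1 oxygen, 1 sulfur; one six-membered aromatic ring of carbon only) in place of a group of 8 heavy atoms (7 carbon, 1 sulfur; one six-membered aromatic ring of carbon only), on an aromatic carbon. The site lies between two ring nitrogen atoms, next to the ring atom that bears an oxan-4-yl group.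

Two measured steps offer some guidance. The closer one is a 2.5-fold higher number from compound 1 to compound 3 (0.40 log units; beyond the scatter), made at the same substituent, with benzyl in place of phenyl on a sulfur. The other is a 6.8-fold higher number from compound 1 to compound 2 (0.83 log units; beyond the scatter), made at the oxan-4-yl group, and it shows only how far a single change has moved this series. Among the compounds with values here, no measured compound carries the added oxygen, so direction remains uncertain. A modest move towards a higher number is expected, with a step within the scatter still possible.

The expected step is a 1.5-fold higher number from compound 3 to compound 4 (0.17 log units; within the scatter). Compound 4 is estimated at 160 nM, with an expected range of 45 nM to 550 nM.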

Compound 4, half-maximal inhibitory concentration: 433 nM
The estimate for compound 4 lay 2.7-fold (0.43 log units) below the measured number; measured number inside the range.
By their numbers in this assay, from the lowest: compound 1; then compound 3; then compounds 2 and 4 (each within the scatter of the next).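

In this assay, the site on the aromatic carbon responds to a change at the sulfur itself, not only to the group carried beyond it: one added oxygen on the benzylsulfanyl sulfur gives a 4.0-fold higher number from compound 3 to compound 4 (0.61 log units; beyond the scatter). Changes at this single site can thus span a 10-fold higher number from compound 1 to compound 4 (1.01 log units; beyond the scatter), so the substituent here is not a tolerant one on this read-out. Nothing at hand explains why the added oxygen moves the number in this direction.

The compounds shown leave open whether a second oxygen on the same sulfur, as in a sulfone, would carry the move further, and whether one added oxygen has a comparable effect on the phenyl-bearing sulfur of compound 1. Going by these compounds, how an amine in place of the sulfur would read at this site is also open.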